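Cytotoxicity series: ethoxy in place of methyl on a carbonyl

This account rests on a few compounds, and the source may have more. Where it says the series, first, only, none or still open, it means among the compounds named here.

Measured in a functional assay on SK-MES-1 cells (Homo sapiens) for cytotoxicity, read by MTT assay, with a stated time of 96 h; a higher number here means that more compound is needed for the effect, a lower number that less compound is needed:
compound 1 `COc1ccc(-c2[nH]c3ccccc3c2/C=C(\C#N)S(=O)(=O)c2ccccc2)cc1` gives 43000 nM
compound 3 `COc1ccc2[nH]c(-c3ccccc3)c(/C=C(\C#N)S(=O)(=O)c3ccccc3)c2c1` gives 12000 nM
compound 2 `CC(=O)/C(=C/c1c(-c2ccccc2)[nH]c2ccccc12)C(=O)c1ccccc1` gives only a limit, > 100000 nM

Among the measured compounds shown here, compound 2 is the one value sitting at the limit of > 100000 nM in this assay, at which 1 of the 3 values shown sits, so no number is known for it; it stands at the top of the series with no measurable effect. Compound 4 `CCOC(=O)/C(=C/c1c(-c2ccccc2)[nH]c2ccccc12)C(=O)c1ccccc1` differs from it in one place: ethoxy in place of methyl on a carbonyl carbon. For the measured compounds named here, no measured pair spans this change; compound 1 and compound 3 differ from compound 2 in several places at once, so their values carry little over. The step from compound 2 to compound 4 in this assay is expected to be small, none beyond the scatter, and most likely to land at a limit again; the expected step is a step that the limit leaves unreadable from compound 2 to compound 4. Compound 4 is estimated at 150000 nM, between 50000 nM and 500000 nM.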

Compound 4, half-maximal effective concentration: > 100000 nM
Compound 4: no number, only a limit (the forecaster's own chance of this, stated with the estimate: 70%); the middle value lies beyond the limit too.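

In this assay compound 2 and compound 4 both give only a limit, not a number, so no step can be read between them: the limit of > 100000 nM in this assay, at which 2 of the 4 values shown sit.

As far as these compounds go, what ethoxy in place of methyl on a carbonyl carbon does to the effect stays open.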